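Naphthyl to hydroxyphenyl on the amine of compound 2

A few compounds are considered here, and "the series" means these few. Any claim that something is new, unique, unknown or untested is made for them only; others in the source may bear on it.

Of the compounds shown here, three sharing one core have been tested in a functional assay on MCF7 cells (Homo sapiens) for cytotoxicity, read by sulforhodamine B assay; a lower number here means a stronger inhibitor, a higher number a weaker inhibitor. Compound 1 `C=C1[C@@H](OC(C)=O)C[C@@H]2[C@](C)(COC=O)[C@H](OC(C)=O)CC[C@@]2(C)[C@@H]1C[C@@H](Nc1cccc2ccccc12)C1=CCOC1=O` gives 9750 nM. Compound 2 `C=C1[C@@H](OC(C)=O)C[C@@H]2[C@](C)(CO[Si](C)(C)C(C)(C)C)[C@H](OC(C)=O)CC[C@@]2(C)[C@@H]1C[C@@H](Nc1cccc2ccccc12)C1=CCOC1=O` gives 5770 nM, the lowest of the three numbers, but its difference from compound 1 is a 1.7-fold lower number from compound 1 to compound 2 (0.23 log units; within the scatter), so the two are not told apart. Compound 3 `C=C1[C@@H](OC(C)=O)C[C@@H]2[C@](C)(COC=O)[C@H](OC(C)=O)CC[C@@]2(C)[C@@H]1C[C@@H](Nc1ccccc1F)C1=CCOC1=O` gives 16400 nM, and it is the only one that stands apart from compound 2 beyond the scatter.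

Compound 4 `C=C1[C@@H](OC(C)=O)C[C@@H]2[C@](C)(CO[Si](C)(C)C(C)(C)C)[C@H](OC(C)=O)CC[C@@]2(C)[C@@H]1C[C@@H](Nc1ccc(O)cc1)C1=CCOC1=O` is not yet measured. It differs from compound 2 in one place: 4-hydroxyphenyl in place of naphthalen-1-yl on an amine nitrogen. Among the measured compounds shown here, the one measured step that bears on this change is the exchange of the same naphthalen-1-yl for a single six-membered ring, 2-fluorophenyl, which gave a 1.7-fold higher number from compound 1 to compound 3 (0.23 log units; within the scatter). On that basis a small move toward a higher number in this assay is expected for compound 4, of a size close to that earlier step, a 1.6-fold higher number from compound 2 to compound 4 (0.22 log units; within the scatter). The estimate for compound 4 is therefore 9500 nM, with a range from 4000 nM to 22000 nM.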

Compound 4, half-maximal inhibitory concentration: 5220 nM
Beside the measured number, compound 4's estimate is 1.8-fold (0.26 log units) above it, and the stated range covers the measured number.
By their numbers in this assay, from the lowest: compounds 4, 2, 1 and 3 (each within the scatter of the next, the first and the last beyond it).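

In this assay, the amine nitrogen of compound 2 takes 4-hydroxyphenyl in place of naphthalen-1-yl with a 1.1-fold lower number from compound 2 to compound 4 (0.04 log units; within the scatter), so the two compounds are not told apart. The earlier exchange at this position, a 1.7-fold higher number from compound 1 to compound 3 (0.23 log units; within the scatter), put in a single ring bearing fluorine; this one shows that a single ring with a hydrogen-bond donor and acceptor also stays within the scatter, here with the silyl ether group of compound 2 in place. No measurement at hand explains this result.

The compounds shown leave open whether 4-hydroxyphenyl reads the same on the otherwise unchanged frame of compound 1. They also leave open how a 4-aminophenyl, a 4-carboxyphenyl or a saturated cyclohexyl group would read on this amine nitrogen.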